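Ethoxy in place of fluoro on compound 2

This account rests on a few compounds, and the source may have more. Where it says the series, first, only, none or still open, it means among the compounds named here.

Three compounds sharing one core have been measured in a functional assay on cells for positive allosteric modulation of G-protein coupled receptor 68 (Homo sapiens), read by a luciferase reporter and cAMP accumulation, with a stated time of 30 min, at pH 6.8 and pH 8.3, in the presence of a further agent that is not named here; a lower number here means a less potent compound, a higher number a more potent compound, by a factor of ten per unit of this negative logarithm:

compound 1 `Nc1nc(NCc2ccccc2F)nc(-c2ccccc2CO)n1` gives 4.27
compound 2 `Nc1nc(NCc2ccc(F)cc2)nc(-c2ccccc2CO)n1` gives 3.97
compound 3 `COc1ccccc1CNc1nc(N)nc(-c2ccccc2CO)n1` gives 3.99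

Compound 2 has the lowest of the three numbers, but its neighbours sit close: the step of a number 0.02 log units higher from compound 2 to compound 3 (within the scatter) and the step of a number 0.30 log units lower from compound 1 to compound 2 (within the scatter) are both within the scatter, so the three measured values cannot be told apart with confidence.

Compound 4 `CCOc1ccc(CNc2nc(N)nc(-c3ccccc3CO)n2)cc1` is not yet measured. It differs from compound 2 in one place: ethoxy in place of fluoro on an aromatic carbon.

Among the compounds with values here, two measured steps bear on this change. The step of a number 0.28 log units lower from compound 1 to compound 3 (within the scatter) exchanges fluoro for methoxy on an aromatic carbon and stays within the scatter. The step of a number 0.02 log units higher from compound 2 to compound 3 (within the scatter) moves the substituent and changes it from fluoro to methoxy at the same time, again within the scatter. Within the data shown here, no measured step puts an ethoxy at this place, so the expectation rests on these alkoxy-for-fluoro exchanges alone.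

On that basis the step from compound 2 to compound 4 is expected to be a number 0.03 log units higher from compound 2 to compound 4 (within the scatter), that is, nothing beyond the scatter. Compound 4 is therefore estimated at 4, with a range from 3.5 to 4.6.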

Compound 4, negative logarithm of the antagonist equilibrium constant: 4.77
Compound 4: the middle estimate sits 0.77 log units below what was measured, and the stated range ends below it.
By their numbers in this assay, from the lowest: compounds 2, 3 and 1 (each within the scatter of the next); then compound 4.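

In this assay, putting ethoxy in place of fluoro on this aromatic carbon, para to a large group, gives a number 0.80 log units higher from compound 2 to compound 4 (beyond the scatter), the first step among these compounds to pass the scatter. Within the data shown here, the earlier exchanges, which moved a fluoro around the ring or swapped it for a methoxy, could not be told apart from repeat measurements, so this position is the first place where a substituent change gives a readable difference. The change replaces one heavy atom with three and adds a hydrogen-bond acceptor, but nothing measured here explains why the number moves.

Among these compounds, these compounds do not show whether the oxygen alone is enough or whether the whole ethoxy is needed, since no compound carries a methoxy on this same carbon. Nor do they show how far the trend runs: a longer chain such as propoxy, or a different kind of group such as an amine, on this carbon could separate the two readings and show whether there is further room here.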